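This account rests on a few compounds, and the source may have more. Where it says the series, first, only, none or still open, it means among the compounds named here.

The three measured compounds share one core. Compound 1 `Nc1nc2c(nc(I)n2COCCO)c(=O)[nH]1` carries iodo on the aromatic carbon, and in a functional assay on L1210 cells (Mus musculus) for inhibition (on this read-out higher numbers stand for weaker inhibition and lower numbers for stronger inhibition), compound 1 gives only a limit, > 1000 ug/mL. Compound 2 `Nc1nc2c(nc(O)n2COCCO)c(=O)[nH]1` has hydroxy in place of iodo, and in this assay compound 2 also gives a limit, > 500 ug/mL. Within the data shown here, compound 3 `Nc1nc2c(nc(N)n2COCCO)c(=O)[nH]1` has amino at that carbon, and in this assay compound 3 gives 500 ug/mL, the one real number among the three. The step that the two limits leave unreadable from compound 1 to compound 2 cannot be read because the limit of > 1000 ug/mL in this assay, at which 1 of the 3 values shown sits, and the limit of > 500 ug/mL in this assay, at which 1 of the 3 values shown sits, stand at its two ends. The step of an at least 2.0-fold lower number from compound 1 to compound 3 (0.30 log units; that floor lies within the scatter) has a floor that sits within the scatter, and a number no higher from compound 2 to compound 3 (the limit leaves the size open) is open in size. Compound 3 thus stands as the single readable point, the other two resting at limits.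

Compound 4 `CNc1nc2c(=O)[nH]c(N)nc2n1COCCO` differs from compound 3 by methyl in place of hydrogen on a nitrogen on an aromatic ring. Among the measured compounds shown here, none of the measured steps touches this nitrogen; all three vary the group on the aromatic carbon. No measured step therefore bears on the change, and no direction can be argued from the numbers shown. The expectation is a number close to that of compound 3, with no change at the digits printed from compound 3 to compound 4 (within the scatter) expected to lie within the scatter. Compound 4 is estimated at 500 ug/mL, between 150 ug/mL and 1500 ug/mL, with a real chance that only a limit is reported.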

Compound 4, concentration for 50% inhibition: > 500 ug/mL
Compound 4 ended at the assay's limit; the forecaster's own chance of this, stated with the estimate: 40%; the middle value lies on the limit itself.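

In this assay compound 4 gives only a limit, > 500 ug/mL. Methyl in place of hydrogen on the nitrogen brings a number no lower from compound 3 to compound 4 (the limit leaves the size open), which gives the first read on a change at this nitrogen rather than at the group on the aromatic carbon: the direction is bounded, but the size stays open. The steps joining compound 4 to compound 1 and to compound 2 cannot be read, with limits at both ends of each, and the count of values resting at the lower limit has grown: the limit of > 500 ug/mL in this assay, at which 2 of the 4 values shown sit.

The compounds shown leave open how far past the limit methylamino lies, so it remains unknown whether this methyl costs little or much, and compound 3 remains the only compound with a real number. They also leave open how a dimethylamino group, or an ethyl or longer chain on this nitrogen, would read in this assay.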